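A few compounds are considered here, and "the series" means these few. Any claim that something is new, unique, unknown or untested is made for them only; others in the source may bear on it.

Of the compounds shown here, three have been measured in an assay on mitochondria for inhibition of Amine oxidase [flavin-containing] A (Bos taurus), read by fluorescence; on this read-out lower numbers stand for stronger inhibition and higher numbers for weaker inhibition. Compound 1 `CN(Cc1ccccc1)Cc1ccc[nH]1` gives 3500 nM, compound 2 `O=C(NCCCCc1ccccc1)c1ccc[nH]1` gives 55 nM, and compound 3 `C[C@H](C1CCCCC1)N(C)C(=O)c1ccc[nH]1` gives 1.7 nM, the lowest of the three numbers; compound 2 stands nearest to compound 3 and compound 1 furthest, both gaps beyond the scatter. Among the measured compounds shown here, compound 4 `C[C@@H](C1CCCCC1)N(C)C(=O)c1ccc[nH]1` has not yet been measured. the two compounds have the same atoms and bonds and differ only in configuration as drawn: 1 of 1 stereo elements differ; a stereocentre at a saturated chain carbon is drawn R in compound 3 and S in compound 4 No measured pair in this set shows a change of this kind, so the size of the step cannot be read from the other compounds. Compound 4 is expected to inhibit less strongly than its mirror image, with an expected step of a 12-fold higher number from compound 3 to compound 4 (1.07 log units; beyond the scatter). The estimate for compound 4 in this assay is 20 nM, with a range from 3 nM to 150 nM.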

Compound 4, inhibition constant: 20 nM
Compound 4: middle estimate and measured number agree at the digits printed, within the range that was stated.
By their numbers in this assay, from the lowest: compound 3; then compound 4; then compound 2; then compound 1.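

Turning the stereocentre at a saturated chain carbon from R to S gives a 12-fold higher number from compound 3 to compound 4 (1.07 log units; beyond the scatter), so this position answers to configuration alone, with nothing entering or leaving. The earlier compounds shown here differ in more than one place and could not show this. The step can be placed on that stereocentre because no other feature changes: the fact that compounds 3 and 4 differ only in the configuration as drawn

The compounds shown leave open whether R stays favoured with a longer chain at that stereocentre. They also leave open whether a step of this size persists with an amine or a carboxylic acid on the shared core.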